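A Methyl Removed: Compound 3 to Compound 4

The source may hold more compounds than are shown below. What is called first, only, known or untested is meant among the compounds shown, and "the series" means these compounds.

Compound 1 `COc1cnc(-c2ccccn2)nc1NCc1ccccc1Cl` gives 55 mL/min/kg in an in vitro ADME assay on microsomes from liver (Homo sapiens) for metabolic stability, read by LC-MS, tested at 0.05 uM; a higher number here means faster removal of the compound, a lower number slower removal.
Compound 2 `COc1cnc(-c2ccccn2)nc1NC1CCCC1` gives 210 mL/min/kg in this assay.
Compound 3 `COc1cnc(-c2ccccn2)nc1NCc1ccccc1C` gives 55 mL/min/kg in this assay.

Compound 3 stands level with compound 1, the two together holding the lowest numbers of the three, while compound 2 sits clearly higher. Compound 4 `COc1cnc(-c2ccccn2)nc1NCc1ccccc1` differs from compound 3 in one place: hydrogen in place of methyl on an aromatic carbon. Going by the values given here, the only measured step touching this ring, no change at the digits printed from compound 1 to compound 3 (within the scatter), exchanged one substituent for another without moving the number; no measured step removes the substituent altogether, so the data give no direct guide. A shift in this assay beyond the scatter is therefore not expected, though a modest rise cannot be ruled out. Compound 4 is expected to give 70 mL/min/kg, between 35 mL/min/kg and 140 mL/min/kg, meaning an expected 1.3-fold higher number from compound 3 to compound 4 (0.10 log units; within the scatter).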

Compound 4, clearance: 67 mL/min/kg
Estimate against measurement, compound 4: 1.0-fold (0.02 log units) above, and the stated range covers the measured number.
By their numbers in this assay, from the lowest: compounds 1, 3 and 4 (each within the scatter of the next); then compound 2.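

In this assay this position turns out to need no substituent at all: hydrogen in place of methyl (a 1.2-fold higher number from compound 3 to compound 4 (0.09 log units; within the scatter)) and hydrogen in place of chloro (a 1.2-fold higher number from compound 1 to compound 4 (0.09 log units; within the scatter)) both stay within the scatter. The gap to the cyclopentyl compound also holds for the plain benzyl group (a 3.1-fold lower number from compound 2 to compound 4 (0.50 log units; beyond the scatter)), so it does not rest on the methyl or the chloro. On these data alone, whether an amine or a trifluoromethyl group here would also leave the number in place remains open. Nothing available explains why these numbers stand as they do.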